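Permeability of a Benzyl Analogue on the Shared Core

The compounds below may be only part of what the source reports. "The series", "measured", "known", "first", "only" and "open" are said of these compounds alone.

Measured so far:
compound 1 `Fc1ccc(-c2ccc3c(NCCCNCc4ccco4)ccnc3c2)cc1` gives 237 10^-6 cm/s
compound 2 `COc1ccc(F)cc1CNCCCNc1ccnc2cc(Cc3ccccc3)ccc12` gives 23 10^-6 cm/s
compound 3 `CC(C)(C)c1ccc(-c2ccc3c(NCCCNCc4ccco4)ccnc3c2)cc1` gives 237 10^-6 cm/s

The three measured compounds were tested in an ADME assay for permeability, using PAMPA, with a stated time of 30 min, at pH 7.4; a higher number here means that the compound crosses the layer faster, a lower number that the compound crosses the layer more slowly. Compound 3 stands level with compound 1 at the digits shown, and together they give the highest of the three numbers. Compound 2 gives the lowest number, and the gap from compound 3 down to compound 2 lies beyond the scatter. Going by the values given here, the only one-step comparison among the measured compounds is no change at the digits printed from compound 1 to compound 3 (within the scatter); that step, tert-butyl in place of fluoro on an aromatic carbon, left the number unchanged within the scatter.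

Compound 4 `c1ccc(Cc2ccc3c(NCCCNCc4ccco4)ccnc3c2)cc1` is the next compound to be measured. It differs from compound 3 as follows: benzyl in place of 4-(tert-butyl)phenyl on an aromatic carbon.

Among the compounds with values here, no measured step bears directly on this change. Within the data shown here, the one measured step touches only the group on the distant aromatic ring and showed no change, so it says nothing about swapping an aryl group for benzyl. Compound 2, which carries the same benzyl group on the shared core, gives 23 10^-6 cm/s, but it also differs from compound 4 in the other part of the molecule, so it is not a clean comparison. Compound 4 is therefore expected to land below compound 3, with wide uncertainty, a step of a 1.8-fold lower number from compound 3 to compound 4 (0.26 log units; within the scatter). The estimate for compound 4 is 130 10^-6 cm/s, with a range from 35 10^-6 cm/s to 300 10^-6 cm/s.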

Compound 4, apparent permeability: 23 10^-6 cm/s
The estimate for compound 4 lay 5.7-fold (0.75 log units) above the measured number, outside the stated range (below it).
By their numbers in this assay, from the lowest: compounds 2 and 4 (each within the scatter of the next); then compounds 1 and 3 (each within the scatter of the next).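

In this assay, benzyl in place of 4-(tert-butyl)phenyl on this aromatic carbon gave a 10-fold lower number from compound 3 to compound 4 (1.01 log units; beyond the scatter), and benzyl in place of 4-fluorophenyl gave a 10-fold lower number from compound 1 to compound 4 (1.01 log units; beyond the scatter), so this position does respond to a change of group, although the earlier exchange of tert-butyl for fluoro on the distant ring gave no change at the digits printed from compound 1 to compound 3 (within the scatter). With benzyl in this position, furan-2-yl in place of 5-fluoro-2-methoxyphenyl on the saturated chain carbon bound to an amine nitrogen gave no change at the digits printed from compound 2 to compound 4 (within the scatter), so that change at the other end of the molecule left the number as it was. No measurement shown here accounts for the loss on moving to benzyl.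

The compounds shown leave open whether the lower number belongs to the benzyl group itself or would also follow from other groups on this aromatic carbon, such as phenoxy, 2-phenylethyl or a pyridine ring. They also leave open whether 5-fluoro-2-methoxyphenyl on the chain would match furan-2-yl as closely when 4-fluorophenyl, rather than benzyl, sits on the shared core.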